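Cyclohexyl replacing 2-methoxybenzyl on the imidazole-bearing series

A few compounds are considered here, and "the series" means these few. Any claim that something is new, unique, unknown or untested is made for them only; others in the source may bear on it.

Of the compounds shown here, two share the core and have been measured in an in vitro functional assay on cells for agonist activity at Bombesin receptor subtype-3 (Mus musculus), read by luminescence and calcium flux; a lower number here means that less compound is needed, a higher number that more compound is needed for the effect. Compound 1 `CCCCc1cnc(C(CC)Cc2ccc(-c3ccccc3C(=O)O)cc2)[nH]1` carries butyl on the five-membered ring and an ethyl branch on the linker; in this assay compound 1 gives 340 nM. Compound 2 `COc1ccccc1Cc1cnc(CCc2ccc(-c3ccccc3C(=O)O)cc2)[nH]1` carries 2-methoxybenzyl on the ring and an unbranched linker; in this assay compound 2 gives 163 nM. Of the two numbers, compound 2 gives the lower one, and the gap to compound 1 lies beyond the usual scatter, so compound 2 stands as the more potent of the pair.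

Compound 3 `O=C(O)c1ccccc1-c1ccc(CCc2ncc(C3CCCCC3)[nH]2)cc1` differs from compound 2 in a single place: cyclohexyl in place of 2-methoxybenzyl on an aromatic carbon. The aromatic ring with its methoxy group is lost and a saturated ring of six carbons takes its place, with no change elsewhere. Compound 1 shows that an aliphatic group at this position is tolerated but gives the higher number of the two, so a modest loss is expected: the step of a 1.8-fold higher number from compound 2 to compound 3 (0.26 log units; within the scatter) is expected to run upward, roughly at the edge of the scatter. Compound 3 is therefore estimated at 300 nM, with a range from 100 nM to 1000 nM.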

Compound 3, half-maximal effective concentration: 14.7 nM
For compound 3 the middle estimate is 20-fold (1.31 log units) above the measured one, and the stated range ends above it.
By their numbers in this assay, from the lowest: compound 3; then compound 2; then compound 1.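

This position on the five-membered aromatic ring proves far more sensitive than the pair of compound 1 and compound 2 could show, since those two differ in more than one place. With the unbranched linker and the rest of the core held constant, this assay gives an 11-fold lower number from compound 2 to compound 3 (1.04 log units; beyond the scatter) for cyclohexyl in place of 2-methoxybenzyl, so neither the aromatic ring of that group nor its methoxy oxygen is required for activity in this pair. The same step removes the aromatic ring and the hydrogen-bond acceptor and also makes the group smaller, and no measurement at hand gives a reason for its size.

The compounds shown leave open which of these changes carries the step: plain benzyl or phenyl at this position would separate the methoxy group from the aromatic ring, and cyclopentyl or cycloheptyl would show how much ring size matters. Also open, from the compounds shown here alone, is whether the gain from cyclohexyl holds with the ethyl branch on the linker, or when a hydroxyl or an amine is placed on the cyclohexyl ring.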